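Swapping the aryl tail on a piperazine amide

A few compounds are considered here, and "the series" means these few. Any claim that something is new, unique, unknown or untested is made for them only; others in the source may bear on it.

Measured so far:
- compound 1, `NC(COCc1ccccc1)c1cc(F)ccc1N1CCN(C(=O)CCc2ccc(Cl)cc2Cl)CC1`: 1000 nM in an assay on HEK293 cells for displacement of a labelled ligand from Melanocortin receptor 4 (Homo sapiens); on this read-out lower numbers stand for stronger inhibition and higher numbers for weaker inhibition
- compound 2, `CCC(C)[C@H](N)c1cc(C(F)(F)F)ccc1N1CCN(C(=O)CCc2ccc(OC)c(OC)c2Cl)CC1`: 2500 nM in this assay
- compound 3, `CC(C)C[C@H](N)c1cc(C(F)(F)F)ccc1N1CCN(C(=O)CCc2cccc(C(F)(F)F)c2)CC1`: 2200 nM in this assay

Compound 3 has the second highest of the three numbers. Its value and that of compound 2 lie within the scatter of each other, so nothing separates them. Compound 1 gives a lower number, and that gap is beyond the scatter; compound 1 differs from compound 3 in more than one place, however, so it offers no direct guide to a single change.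

The next compound, compound 4, `CC(C)C[C@H](N)c1cc(C(F)(F)F)ccc1N1CCN(C(=O)CCc2c(Cl)cccc2Cl)CC1`, differs from compound 3 in one place: 2,6-dichlorophenyl in place of 3-(trifluoromethyl)phenyl on a saturated chain carbon, two bonds along the chain from a carbonyl carbon. Going by the values given here, no measured pair shows this swap, so the expectation rests on the general run of the numbers, which sit close together. The step from compound 3 to compound 4 is expected to be a 1.5-fold lower number from compound 3 to compound 4 (0.17 log units; within the scatter), small and probably not far beyond the scatter, if anything toward a lower number. Compound 4 is therefore estimated at 1500 nM, with a range from 500 nM to 5000 nM.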

Compound 4, inhibition constant: 2600 nM
Estimate against measurement, compound 4: 1.7-fold (0.24 log units) below; low and high end bracket the measured number.
By their numbers in this assay, from the lowest: compound 1; then compounds 3, 2 and 4 (each within the scatter of the next).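

Going by these compounds alone, replacing 3-(trifluoromethyl)phenyl with 2,6-dichlorophenyl on the saturated chain carbon, two bonds along the chain from a carbonyl carbon, gives a 1.2-fold higher number from compound 3 to compound 4 (0.07 log units; within the scatter), the first direct reading at this position. With the rest of the molecule held constant, these two differently substituted aryl tails cannot be told apart on this read-out, so this swap neither gains nor loses measurable binding. No supporting measurement is available to explain this result.

Whether any tail at this position can shift the number beyond the scatter remains open, since an unsubstituted phenyl, a pyridine ring or a longer chain is not among the compounds shown. Compound 1 still stands apart, but it differs from compound 3 in more than one place, so its number cannot be traced to any single group.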